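Azido to (carboxymethyl)amino on a nucleoside: expected tolerance

The source may hold more compounds than are shown below. What is called first, only, known or untested is meant among the compounds shown, and "the series" means these compounds.

Measured so far:
compound 1 `[N-]=[N+]=NCc1ncnc2c1ncn2[C@@H]1O[C@H](CO)[C@@H](O)[C@H]1O` gives > 250000 nM
compound 2 `OC[C@H]1O[C@@H](n2cnc3c(CSc4ccccn4)ncnc32)[C@H](O)[C@@H]1O` gives > 100000 nM
compound 3 `CN(Cc1ccccc1)Cc1ncnc2c1ncn2[C@@H]1O[C@H](CO)[C@@H](O)[C@H]1O` gives 9000 nM

Three nucleosides sharing one core were tested in a functional assay on Huh-7 cells (Homo sapiens) for cytotoxicity, read by MTT assay, with a stated time of 3 days; a higher number here means that more compound is tolerated, a lower number that less compound is tolerated. Compound 1 reaches only a limit of the assay, (the limit of > 250000 nM in this assay, at which 1 of the 3 values shown sits). Compound 2 likewise sits at a limit, (the limit of > 100000 nM in this assay, at which 1 of the 3 values shown sits). Compound 3 alone gives a number, and the change from compound 1 is an at least 27-fold lower number from compound 1 to compound 3 (1.44 log units; beyond the scatter); the change from compound 2 is an at least 11-fold lower number from compound 2 to compound 3 (1.04 log units; beyond the scatter). Between compound 1 and compound 2 the step is a step that the two limits leave unreadable from compound 1 to compound 2.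

Compound 4 `O=C(O)CNCc1ncnc2c1ncn2[C@@H]1O[C@H](CO)[C@@H](O)[C@H]1O` differs from compound 1 by (carboxymethyl)amino in place of azido on a saturated chain carbon bound to an aromatic carbon. For the measured compounds named here, the only readable step from compound 1, that to compound 3, brings in a different group from the one entering here, so it gives limited guidance. Since compound 1 stands at a limit, any step from it is expected to remain unreadable, with compound 4 most likely also reported at a limit rather than with a number. Compound 4 is therefore estimated at 250000 nM, with a range from 80000 nM to 1000000 nM, which would mean a step of a number no higher from compound 1 to compound 4 (the limit leaves the size open).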

Compound 4, half-maximal cytotoxic concentration: > 100000 nM
Compound 4: only a limit was reported (the forecaster's own chance of this, stated with the estimate: 80%); the middle value is on the limit's open side.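

For the compounds shown here, compound 4 stops at a limit of this assay, which is the first time an amine on this saturated chain carbon bound to an aromatic carbon does not give a number: the limit of > 100000 nM in this assay, at which 2 of the 4 values shown sit.

Replacing benzyl(methyl)amino with (carboxymethyl)amino gives an at least 11-fold higher number from compound 3 to compound 4 (1.04 log units; beyond the scatter) and so shows that a nitrogen on this carbon does not by itself bring the low number of compound 3. The steps that link compound 4 with compound 1 and compound 2 cannot be read, since both ends of each are limits.

The compounds shown leave open whether the phenyl ring of compound 3 goes with its low number, which a dimethylamino or a benzylamino group at this place could test. They also leave open whether the carboxylic acid of compound 4 or its secondary amine goes with the tolerance, which the corresponding methyl ester could begin to separate.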